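The compounds below may be only part of what the source reports. "The series", "measured", "known", "first", "only" and "open" are said of these compounds alone.

In an ADME assay on HEK-293T cells (Homo sapiens) for cytotoxicity, read by MTT assay, with a stated time of 24 h (on this read-out higher numbers stand for lower toxicity in this test and lower numbers for higher toxicity in this test), compound 1 `O=S(=O)(c1ccccc1)n1c(-c2cn(-c3ccccc3)nc2-c2ccc(C(F)(F)F)cc2)nc2ccccc21` gives 128000 nM and compound 2 `Cc1ccc(C)c(S(=O)(=O)n2c(-c3cn(-c4ccccc4)nc3-c3ccc(C(F)(F)F)cc3)nc3ccccc32)c1` gives 223000 nM, so the two values lie within the scatter of each other. Compound 3 `O=S(=O)(c1ccc(Br)cc1)n1c(-c2cn(-c3ccccc3)nc2-c2ccc(C(F)(F)F)cc2)nc2ccccc21` has 4-bromophenyl in place of 2,5-dimethylphenyl on a sulfonyl sulfur. For the measured compounds named here, the only measured step bearing on this change is a 1.7-fold higher number from compound 1 to compound 2 (0.24 log units; within the scatter), which stays within the scatter, and no compound with 4-bromophenyl has yet been measured. No step beyond the scatter is therefore expected, though the range is kept wide. For compound 3 the expected value is 160000 nM, with an estimated range from 70000 nM to 350000 nM. This estimate means an expected 1.4-fold lower number from compound 2 to compound 3 (0.14 log units; within the scatter).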

Compound 3, half-maximal cytotoxic concentration: 185000 nM
Beside the measured number, compound 3's estimate is 1.2-fold (0.06 log units) below it; the range from low to high includes it.
By their numbers in this assay, from the lowest: compounds 1, 3 and 2 (each within the scatter of the next).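

Across the compounds tested in this assay, the group on the sulfonyl sulfur now carries bromine as well as methyl groups, and neither new step leaves the scatter: 4-bromophenyl in place of 2,5-dimethylphenyl (a 1.2-fold lower number from compound 2 to compound 3 (0.08 log units; within the scatter)) and bromo in place of hydrogen on an aromatic carbon (a 1.4-fold higher number from compound 1 to compound 3 (0.16 log units; within the scatter)). Among these three compounds, then, this position shows no step beyond the scatter. Nothing available bears on the reason for these values.

Still open, from the compounds shown here alone, is whether an amine or a carboxylic acid on this aromatic ring, or a longer alkyl chain in its place on the sulfonyl sulfur, would move the number beyond the scatter.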